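Swapping an amino group for trifluoromethyl on an indole core

The source may report more compounds than this note shows. Statements on the series, on what has been measured and on what is new or still open speak of the compounds shown alone.

Measured compounds:
- Compound 1 `CC1CN(CCn2ccc3ccc(Br)cc32)CCN1`: 52%
- Compound 2 `CN1CCCN(CCn2ccc3ccc(Cl)cc32)CC1`: 85%
- Compound 3 `CN1CCCN(CCn2ccc3ccc(N)cc32)CC1`: 0%

The read-out here is an assay on HEK293 cells for binding affinity to 5-hydroxytryptamine receptor 7 (Homo sapiens), read by radioligand binding, tested at 1 uM; a higher number here means more inhibition at the concentration tested (going by the name of the read-out), a lower number less inhibition. Compound 3 stands lowest of the three numbers: in this assay compound 3 gives 0%, while compound 1 gives 52% and compound 2 gives 85%, both beyond the scatter above it.

The unmeasured compound 4 `CN1CCCN(CCn2ccc3ccc(C(F)(F)F)cc32)CC1` differs from compound 3 in one place: trifluoromethyl in place of amino on an aromatic carbon. Among the compounds with values here, the one measured step that bears on this position is a number 85 percentage points lower from compound 2 to compound 3 (beyond the scatter), a large loss when a halogen gave way to amino. Running that change the other way, from amino to a non-amino group, suggests a large gain. Within the data shown here, no trifluoromethyl compound has been measured, so how far the number climbs back toward compound 2 is uncertain. The step of a number 65 percentage points higher from compound 3 to compound 4 (beyond the scatter) is expected to be large and upward. For compound 4 the estimate in this assay is 65%, within a range from 30% to 95%.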

Compound 4, a percentage reported as inhibition, at one concentration (the size of the read-out at that concentration, not a potency): 89%
Compound 4: middle estimate off by 24 percentage points, on the low side, and the stated range covers the measured number.
By their numbers in this assay, from the lowest: compound 3; then compound 1; then compounds 2 and 4 (each within the scatter of the next).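

In this assay, replacing amino with trifluoromethyl gives a number 89 percentage points higher from compound 3 to compound 4 (beyond the scatter), so this position can carry a high number when amino is absent, and a second non-amino group now shows this alongside chloro. Chloro and trifluoromethyl cannot be told apart here, as the change between them gives a number 4 percentage points higher from compound 2 to compound 4 (within the scatter), which leaves amino as the group that stands apart among the three at this position. Nothing available explains why these groups differ as they do.

On these data alone, it remains open whether a group such as methoxy, nitrile or methyl would keep the number high or lose it as amino does. Also open, as far as these compounds go, is whether trifluoromethyl would give a similar reading on the side chain of compound 1, and how the high readings at this single concentration would translate into potency.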